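Tetrazolyl thioacetohydrazone series: fluoro to bromo exchange

The source may hold more compounds than are shown below. What is called first, only, known or untested is meant among the compounds shown, and "the series" means these compounds.

Measured compounds:
compound 1 `Cn1nnnc1SCC(=O)N/N=C/c1ccc(F)cc1` — 3160000 nM
compound 2 `Cn1nnnc1SCC(=O)N/N=C/c1ccccc1[N+](=O)[O-]` — 1600000 nM
compound 3 `Cn1nnnc1SCC(=O)N/N=C/c1ccccc1F` — 9000000 nM

All three were read in a functional assay on A549 cells (Homo sapiens) for cytotoxicity, read by XTT assay, with a stated time of 24 h; on this read-out higher numbers stand for weaker inhibition and lower numbers for stronger inhibition. Compound 3 gives the highest number of the three; compound 1 sits nearest to it, and compound 2 gives the lowest number of the set. Going by the values given here, the one single-point step among the measured compounds is a 5.6-fold higher number from compound 2 to compound 3 (0.75 log units; beyond the scatter), a fluoro in place of nitro on an aromatic carbon.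

Compound 4 `Cn1nnnc1SCC(=O)N/N=C/c1ccccc1Br` differs from compound 3 by bromo in place of fluoro on an aromatic carbon. Among the compounds with values here, no measured step covers a halogen-for-halogen exchange, so the change from compound 3 to compound 4 has no direct precedent in this set; the step from compound 2 to compound 3 concerns a different entering group and bears on it only loosely, showing that a swap at this aromatic carbon can move the number beyond the scatter. With no closer guide, the expectation for compound 4 is a number near that of compound 3, with a slight lean toward a lower number, expressed as a 1.8-fold lower number from compound 3 to compound 4 (0.26 log units; within the scatter). Compound 4 is therefore estimated at 5000000 nM, with a range from 1500000 nM to 15000000 nM.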

Compound 4, half-maximal inhibitory concentration: 2000000 nM
Estimate against measurement, compound 4: 2.5-fold (0.40 log units) above; the measured number falls inside the stated range.
By their numbers in this assay, from the lowest: compounds 2, 4 and 1 (each within the scatter of the next); then compound 3.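

In this assay, a 4.5-fold lower number from compound 3 to compound 4 (0.65 log units; beyond the scatter) shows that exchanging one halogen for another on this aromatic carbon, ortho to a large group, is enough by itself to move the number beyond the scatter; the earlier step, which replaced nitro, could not show this. Read beside it, a 1.3-fold higher number from compound 2 to compound 4 (0.10 log units; within the scatter) puts bromo and nitro together at this place, so among the three groups compared here, fluoro is the one that stands apart, in line with a 5.6-fold higher number from compound 2 to compound 3 (0.75 log units; beyond the scatter). The data offer nothing that accounts for this separation of fluoro from bromo and nitro.

The compounds shown leave open whether chloro, methoxy or an amine at this place would read with fluoro or with bromo and nitro, and so whether the separation follows any order across groups or is particular to fluoro. They also leave open whether the same exchange of fluoro for bromo on compound 1 would give a step of similar size, and whether the pairing of bromo with nitro would hold in any read-out other than this assay.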